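The source may report more compounds than this note shows. Statements on the series, on what has been measured and on what is new or still open speak of the compounds shown alone.

Compound 1 (`Nc1ncc(-c2ccccc2)c(-c2ccncc2)n1`) and compound 2 (`CC(C)(C)c1ccnc(N)n1`) were both tested in a functional assay on the whole organism for inhibition, with Rattus norvegicus as the target, with stated times of 1 h and 3.5 h, at a dose of 100 mg/kg by the oral route; on this read-out lower numbers stand for less inhibition and higher numbers for more inhibition at the one dose given (going by the name of the read-out). In this assay compound 1 gives 48%. In this assay compound 2 gives 32%. Among the measured compounds shown here, of the two numbers known, that of compound 2 is the lower, and its distance from compound 1 is beyond the usual scatter of repeated measurements; no computed step between these two compounds is available, so only the two values themselves can be compared.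

Compound 3 (`CC(C)(C)Nc1nccc(C(C)(C)C)n1`) has not yet been measured in this assay. It differs from compound 2 in one place: tert-butyl in place of hydrogen on a nitrogen on an aromatic ring. For the measured compounds named here, no pair of measured compounds shows the effect of such a change, so there is no measured step to guide the expectation.

On that basis the step from compound 2 to compound 3 in this assay is expected to be small, a number 3 percentage points higher from compound 2 to compound 3 (within the scatter), and not beyond the scatter in either direction. Compound 3 is therefore estimated to give 35% in this assay, within a range from 15% to 60%.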

Compound 3, a percentage reported as inhibition, in the whole organism at one dose (the size of the read-out at that dose, not a potency): 26%
The estimate for compound 3 lay 9 percentage points above the measured number; the measured number falls inside the stated range.
By their numbers in this assay, from the lowest: compounds 3 and 2 (each within the scatter of the next); then compound 1.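

In this assay, the change from amino to (tert-butyl)amino, with tert-butyl in place of hydrogen on a nitrogen on an aromatic ring, gives a number 6 percentage points lower from compound 2 to compound 3 (within the scatter). Among the compounds shown here, this is the first measured step at this position, and it shows that this nitrogen can carry a tert-butyl group, with its four carbon atoms and no ring, without the read-out at the one oral dose moving beyond the usual scatter from that of compound 2. Nothing available explains this outcome or says what the added group does in the whole animal.

The compounds shown leave open whether a smaller group such as methyl, a longer chain such as n-butyl, or an acyl group such as acetyl on the same nitrogen would also stay within the scatter of compound 2, so a single bulky group cannot stand for all substituents at this position. They also leave open whether tert-butyl on the corresponding nitrogen of compound 1, which has a different set of groups on the shared core, would give a similarly small step.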